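Trading a Bromophenyl for a Methyl on the Hydroxyalkyl Chain

The source may hold more compounds than are shown below. What is called first, only, known or untested is meant among the compounds shown, and "the series" means these compounds.

Compound 1 `OCC(O)Cn1nc2c(Br)c(Br)c(Br)c(Br)c2n1`: 1%
Compound 2 `OC(CCn1nc2c(Br)c(Br)c(Br)c(Br)c2n1)c1ccc(Br)cc1`: 0%
Compound 3 `C[C@@H](O)CCn1nc2c(Br)c(Br)c(Br)c(Br)c2n1`: 24%

All three compounds share the same tetrabrominated core and differ only in the hydroxyalkyl chain on the ring nitrogen. In a functional assay on CCRF-CEM cells (Homo sapiens) for antiproliferative activity, read by MTT assay, with a stated time of 48 h, tested at 100 uM (a lower number here means a stronger effect, a higher number a weaker effect of the compound at the concentration tested), compound 2 gives 0%, the lowest of the three numbers. Compound 1 stands within the scatter of compound 2, while compound 3 stands beyond it. For the measured compounds named here, the only measured step, a number 23 percentage points higher from compound 1 to compound 3 (beyond the scatter), concerns a change at a different position of the chain and so does not bear directly on the change considered here.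

The unmeasured compound 4 `CC(O)CCn1nc2c(Br)c(Br)c(Br)c(Br)c2n1` differs from compound 2 as follows: methyl in place of 4-bromophenyl on a saturated chain carbon bound to an oxygen on a saturated carbon and a saturated chain carbon. Going by the values given here, no measured pair makes this exact exchange. Compound 3, however, carries the same methyl at the same place and gives 24% in this assay, and compound 4 is expected to resemble it because compound 3 gives 24%. The expected step is therefore a number 24 percentage points higher from compound 2 to compound 4 (beyond the scatter), upward and beyond the scatter. Compound 4 is estimated at 24% in this assay, with a range from 8% to 42%.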

Compound 4, a percentage reported as activity, at one concentration (the size of the read-out at that concentration, not a potency): 0%
Compound 4: the middle estimate sits 24 percentage points above what was measured; measured number outside the range, below it.
By their numbers in this assay, from the lowest: compounds 2, 4 and 1 (each within the scatter of the next); then compound 3.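

In this assay the exchange of methyl for 4-bromophenyl on a saturated chain carbon bound to an oxygen on a saturated carbon and a saturated chain carbon gives no change at the digits printed from compound 2 to compound 4 (within the scatter) and so shows that the 4-bromophenyl ring is not needed for the read-out at this place. Compound 4 also matches the diol, with a number 1 percentage points lower from compound 1 to compound 4 (within the scatter) for 2-hydroxypropyl in place of 1,2-dihydroxyethyl, so this chain exchange on its own does not separate the two compounds when the stereocentre carries no drawn configuration. The weaker effect of compound 3 therefore cannot be credited to the methyl itself, since a number 24 percentage points lower from compound 3 to compound 4 (beyond the scatter) comes with identical atoms and bonds and leaves a single structural difference between them: the fact that one of compounds 3 and 4 is drawn with a defined configuration and the other without, at the place where they differ.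

The compounds shown leave open how the counterpart drawn S at this stereocentre would read, and whether an amine in place of the hydroxyl on that carbon would keep the effect seen for compound 4. Every number here also comes from a single concentration, so whether compounds 1, 2 and 4 would differ in the strength of their effect at other concentrations remains unresolved.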